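One chloro added to compound 2

A few compounds are considered here, and "the series" means these few. Any claim that something is new, unique, unknown or untested is made for them only; others in the source may bear on it.

Compound 1 (`O=C(Nc1ccc(Cl)cc1Cl)c1cc(F)ccc1O`) gives 1620 nM
Compound 2 (`O=C(Nc1ccc([N+](=O)[O-])cc1)c1cc(F)ccc1O`) gives 2080 nM
Compound 3 (`O=C(Nc1ccccc1)c1cc(F)ccc1O`) gives "not determined" (no result reported)

In a functional assay on NALM-6 cells (Homo sapiens) for cytotoxicity, read by luminescence and CellTiter-Glo, with a stated time of 3 days (a higher number here means a weaker inhibitor, a lower number a stronger inhibitor), compound 2 (at 2080 nM) and compound 1 (at 1620 nM) lie within the scatter of each other, so no order can be read between them. Compound 3 offers no number for comparison.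

Compound 4 (`O=C(Nc1ccc([N+](=O)[O-])cc1Cl)c1cc(F)ccc1O`) is compound 2 with chloro in place of hydrogen on an aromatic carbon. For the measured compounds named here, no measured pair shows this change alone. Compound 1 carries chloro groups and no nitro group, and its value (1620 nM) offers only a loose guide. The expected step (a 2.1-fold lower number from compound 2 to compound 4 (0.32 log units; beyond the scatter)) is modest, towards a lower number, and may stay within the scatter. For compound 4 the estimated value is 1000 nM (expected range 350 nM to 2500 nM).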

Compound 4, half-maximal inhibitory concentration: 910 nM
Estimate against measurement, compound 4: 1.1-fold (0.04 log units) above; low and high end bracket the measured number.
By their numbers in this assay, from the lowest: compounds 4, 1 and 2 (each within the scatter of the next, the first and the last beyond it).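

In this assay, chloro in place of hydrogen, ortho to a large group and meta to a nitro group, gives a 2.3-fold lower number from compound 2 to compound 4 (0.36 log units; beyond the scatter), so this single added atom produces a modest change that clears the scatter. Nitro in place of chloro on an aromatic carbon gives a 1.8-fold lower number from compound 1 to compound 4 (0.25 log units; within the scatter), so that swap shows no readable difference. Nothing measured here explains the chloro step.

From the compounds shown here alone, whether a methyl, a methoxy or an amine at this place would match chloro remains open. Steps involving compound 3 cannot be read.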